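Aryl swap on the shared core, compound 3 to compound 4

The source may hold more compounds than are shown below. What is called first, only, known or untested is meant among the compounds shown, and "the series" means these compounds.

Measured compounds in a functional assay on DU-145 cells (Homo sapiens) for antiproliferative activity, read by MTT assay, with a stated time of 48 h; a higher number here means a weaker inhibitor, a lower number a stronger inhibitor:

Compound 1 `C/C(=C\CC/C(C)=C/CC[C@@H]1[C@@]2(C)CCC(=O)C(C)(C)[C@H]2CC[C@@]1(C)O)CC/C=C(\C)C(=O)OCc1cn(-c2ccccc2C)nn1` gives > 150000 nM, a limit of the assay rather than a number.
Compound 2 `C/C(=C\CC/C(C)=C/CC[C@@H]1[C@@]2(C)CCC(=O)C(C)(C)[C@H]2CC[C@@]1(C)O)CC/C=C(\C)C(=O)OCc1cn(C[C@@H]2O[C@H](n3ccc(=O)[nH]c3=O)[C@H]3OC(C)(C)O[C@H]32)nn1` gives > 150000 nM, likewise a limit of the assay.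
Compound 3 `C/C(=C\CC/C(C)=C/CC[C@@H]1[C@@]2(C)CCC(=O)C(C)(C)[C@H]2CC[C@@]1(C)O)CC/C=C(\C)C(=O)OCc1cn(-c2ccc(F)c(Cl)c2)nn1` gives > 150000 nM, again a limit of the assay.

For the measured compounds named here, compound 3 therefore stands at the same limit as the two other measured compounds; no measured compound gives a number in this assay. Going by the values given here, the one step measured between neighbours that differ in a single place, a step that the two limits leave unreadable from compound 1 to compound 3, cannot be read for size or direction, since both ends sit at the limit. The evidence is summarised by the limit of > 150000 nM in this assay, at which 3 of the 3 values shown sit.

Compound 4 `C/C(=C\CC/C(C)=C/CC[C@@H]1[C@@]2(C)CCC(=O)C(C)(C)[C@H]2CC[C@@]1(C)O)CC/C=C(\C)C(=O)OCc1cn(-c2cccc(F)c2)nn1` differs from compound 3 by 3-fluorophenyl in place of 3-chloro-4-fluorophenyl on an aromatic nitrogen. The change stays on the aromatic nitrogen where the earlier swap was made. Among the compounds with values here, because the limit of > 150000 nM in this assay, at which 3 of the 3 values shown sit, places every measured value, including that of compound 3, at the limit, there is no measured step that gives a size or direction to expect for this change, and the most likely outcome is that compound 4 also reports only a limit in this assay.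

Compound 4 is expected to give 200000 nM, with a range of 100000 nM to 400000 nM. The step this estimate means is a step that the limit leaves unreadable from compound 3 to compound 4, which is expected to lie within the scatter.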

Compound 4, half-maximal inhibitory concentration: > 150000 nM
Compound 4: no number, only a limit (the forecaster's own chance of this, stated with the estimate: 85%); the middle value does not contradict the limit.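

In this assay compound 4 gives > 150000 nM, a limit of the assay and not a number, so the steps to compound 4 from compound 3 and compound 1 cannot be read for size or direction. The compounds shown leave open how the groups on this aromatic nitrogen rank against one another in this assay, and whether any change to the shared core gives a measurable value.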